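Trimming the 4-chlorobenzyl group down to methyl

This account rests on a few compounds, and the source may have more. Where it says the series, first, only, none or still open, it means among the compounds named here.

Measured compounds:
compound 1 `Nc1nc(O)c2c(n1)n(C1OC(CO)[C@@H](O)[C@H]1O)c(=O)n2Cc1ccc(Cl)cc1` 27%
compound 2 `C=CCn1c(=O)n(CCCC)c2nc(N)nc(O)c21` 21%
compound 3 `Nc1nc(O)c2c(n1)n(C1OC(CO)[C@@H](O)[C@H]1O)c(=O)n2Cc1ccc(OCc2ccccc2)cc1` 6%

In a functional assay on YAC-1 cells (Mus musculus) (a lower number here means a smaller maximal response, a higher number a larger maximal response), compound 1 gives the highest of the three numbers; compound 2 lies within the scatter of it, while compound 3 lies beyond. Among the measured compounds shown here, the one step that is counted, a number 21 percentage points lower from compound 1 to compound 3 (beyond the scatter), arises from benzyloxy in place of chloro on an aromatic carbon. Compound 4 `Cn1c(=O)n(C2OC(CO)[C@@H](O)[C@H]2O)c2nc(N)nc(O)c21` differs from compound 1 by hydrogen in place of 4-chlorophenyl on a saturated chain carbon bound to an aromatic nitrogen. No measured step removes the aromatic group itself, so the shown data bear on it only loosely; compound 2, which carries no aromatic group, sits near compound 1. A small decrease or none beyond the scatter is expected, a number 9 percentage points lower from compound 1 to compound 4 (within the scatter). Compound 4 is estimated at 18%, between 8% and 32%.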

Compound 4, largest response reached (reported as maximal response), in percent of the reference or control that the assay uses: 72%
Compound 4: the middle estimate sits 54 percentage points below what was measured; the whole stated range lies below it.
By their numbers in this assay, from the lowest: compound 3; then compounds 2 and 1 (each within the scatter of the next); then compound 4.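

In this assay, replacing 4-chlorophenyl with hydrogen at this saturated chain carbon bound to an aromatic nitrogen gives a number 45 percentage points higher from compound 1 to compound 4 (beyond the scatter), so the aromatic group itself has a large bearing on the maximal response. The earlier step changed only a substituent on that ring, whereas this one shows that the highest response among the compounds with the shared core comes without the ring. The data offer no explanation for the rise.

The compounds shown leave open how the response changes between methyl and 4-chlorobenzyl. Ethyl, a longer chain such as propyl, and unsubstituted benzyl would each fill part of that gap.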